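Chain homologation: working notes on compounds 1 to 3

The source may report more compounds than this note shows. Statements on the series, on what has been measured and on what is new or still open speak of the compounds shown alone.

compound 1 `CCCCCCCCNC[C@@H]1OC[C@H](N)[C@@H]1O` — 13800 nM
compound 2 `CCCCCCCCCCCNC[C@@H]1OC[C@H](N)[C@H]1O` — 10000 nM

Within the data shown here, in a functional assay on PC-3 cells (Homo sapiens) for antiproliferative activity, read by MTT assay, with a stated time of 72 h (on this read-out lower numbers stand for stronger inhibition and higher numbers for weaker inhibition), compound 1 gives 13800 nM, the highest of the two numbers so far. Compound 2 gives 10000 nM in this assay, and that value lies within the scatter of the number for compound 1, so the two cannot be ranked against each other. Among the measured compounds shown here, compounds 1 and 2 differ in more than one place, and no single-change step between measured compounds is available.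

Compound 3 `CCCCCCCCCNC[C@@H]1OC[C@H](N)[C@@H]1O` differs from compound 1 by methyl in place of hydrogen on a saturated chain carbon, eight bonds along the chain from an amine nitrogen. For the measured compounds named here, with no measured step of this kind to lean on, and the two measured values sitting within the scatter of each other, the expectation is a step from compound 1 to compound 3 of a 1.3-fold lower number from compound 1 to compound 3 (0.10 log units; within the scatter), which is no more than the scatter allows, with no clear direction. Compound 3 is therefore expected to give about 11000 nM in this assay, in a range from 5000 nM to 25000 nM.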

Compound 3, half-maximal inhibitory concentration: 2030 nM
Compound 3: the middle estimate sits 5.4-fold (0.73 log units) above what was measured; the whole stated range lies above it.
By their numbers in this assay, from the lowest: compound 3; then compounds 2 and 1 (each within the scatter of the next).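

Methyl in place of hydrogen on a saturated chain carbon, eight bonds along the chain from an amine nitrogen, gives the first single-change step in the series, and in this assay it reads a 6.8-fold lower number from compound 1 to compound 3 (0.83 log units; beyond the scatter). This position is therefore not indifferent to the change: a single methyl moves the number beyond the scatter, which the comparison of compound 1 with compound 2, differing in more than one place, could not show. Nothing on hand offers a reason for the size of this step.

On these data alone, whether ethyl or a longer chain in the same place carries the step further or reverses it stays open, as one step makes no trend. Equally open, as far as these compounds go, is what a hydroxyl or an amine on that same chain carbon would do to the number.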